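The compounds below may be only part of what the source reports. "The series", "measured", "known", "first", "only" and "open" are said of these compounds alone.

Compound 1 `COc1cc2c(Nc3nc4ccc(C(=O)Nc5c(C)cccc5Cl)cc4s3)ncnc2cc1OCCCN1CCC(C)CC1` has the lowest of the two numbers in a functional assay on NCI-H661 cells (Homo sapiens) for cytotoxicity, read by WST assay, with a stated time of 72 h (a higher number here means a weaker inhibitor, a lower number a stronger inhibitor), where compound 1 gives 7900 nM. Going by the values given here, compound 3 `COc1cc2c(Nc3nc4ccc(C(=O)Nc5c(C)cccc5C)cc4s3)ncnc2cc1OCCCN1CCC(C)CC1` gives 72300 nM in this assay; the step of a 9.2-fold higher number from compound 1 to compound 3 (0.96 log units; beyond the scatter) is the one change on an aromatic carbon seen here. Compound 2 `COc1cc2c(Nc3nc4ccc(C(=O)Nc5c(C)cccc5C)cc4s3)ncnc2cc1OCCCN1CCCCC1` reaches only a limit in this assay, > 100000 nM, which is the limit of > 100000 nM in this assay, at which 1 of the 3 values shown sits.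

Compound 4 `COc1cc2c(Nc3nc4ccc(C(=O)Nc5c(C)cccc5Cl)cc4s3)ncnc2cc1OCCCN1CCCC1` differs from compound 1 by pyrrolidin-1-yl in place of 4-methylpiperidin-1-yl on a saturated chain carbon, three bonds along the chain from an oxygen on an aromatic ring. Among the compounds with values here, this change touches the saturated ring at the end of the chain, and the one measured change to that ring, an at least 1.3-fold lower number from compound 2 to compound 3 (0.14 log units; that floor lies within the scatter), stayed within the scatter, although it was a smaller change than the present one. From compound 1 a step of no more than modest size is therefore expected in this assay, with its direction open, namely a 1.5-fold higher number from compound 1 to compound 4 (0.18 log units; within the scatter). Compound 4 is estimated at 12000 nM in this assay, with a range from 4000 nM to 40000 nM.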

Compound 4, half-maximal inhibitory concentration: 45500 nM
Compound 4: middle estimate off by 3.8-fold (0.58 log units), on the low side; the whole stated range lies below it.
By their numbers in this assay, from the lowest: compound 1; then compounds 4 and 3 (each within the scatter of the next). At a limit, above all of these: compound 2.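

In this assay, the saturated ring at the end of the chain proves able to move the number beyond the scatter: pyrrolidin-1-yl in place of 4-methylpiperidin-1-yl gives a 5.8-fold higher number from compound 1 to compound 4 (0.76 log units; beyond the scatter). Going by these compounds alone, the earlier change to this ring, an at least 1.3-fold lower number from compound 2 to compound 3 (0.14 log units; that floor lies within the scatter), started from a limit, so its true size could not be read, and this is the first step here at that position with a measured number at both ends. Nothing shown here explains why this change raises the number.

Compound 4 differs from compound 1 in both ring size and the loss of the methyl, so the compounds shown cannot separate these two changes on this core. From the compounds shown here alone, how a morpholin-4-yl ring or an open-chain dimethylamino group at the chain end would read in this assay also remains open.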